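A few compounds are considered here, and "the series" means these few. Any claim that something is new, unique, unknown or untested is made for them only; others in the source may bear on it.

Measured compounds:
Compound 1 `Nc1ccccc1NC(=O)c1ccc(CSC(=S)N2CCN(Cc3ccccn3)CC2)cc1` gives 65.2%
Compound 2 `Nc1ccccc1NC(=O)c1ccc(CSC(=S)N2CCN(c3ccc(Cl)cc3)CC2)cc1` gives 17.2%
Compound 3 `CN(Cc1ccncc1)C(=S)SCc1ccc(C(=O)Nc2ccccc2N)cc1` gives 83.2%

These numbers come from a functional assay on MGC-803 cells (Homo sapiens) for antiproliferative activity, read by CCK-8 assay, with a stated time of 72 h, tested at 8 uM; on this read-out higher numbers stand for a stronger effect at the one concentration tested and lower numbers for a weaker effect. Among the three, compound 2 stands lowest, and its distance from both compound 1 and compound 3 lies beyond the scatter, so its weak read-out is a real difference rather than noise.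

Compound 4 `Nc1ccccc1NC(=O)c1ccc(CSC(=S)N2CCN(c3ccncc3)CC2)cc1` has not yet been measured. It differs from compound 2 in one place: pyridin-4-yl in place of 4-chlorophenyl on an amine nitrogen in a ring.

For the measured compounds named here, one measured step bears on this change: a number 48 percentage points lower from compound 1 to compound 2 (beyond the scatter). That step swapped the group on the same ring nitrogen, and the arrival of 4-chlorophenyl coincided with a large loss of effect. Compound 4 removes 4-chlorophenyl again, though what enters is pyridin-4-yl rather than (pyridin-2-yl)methyl, so the step is not the exact reverse. Going by the values given here, compound 3 gives a high number, but no single-point step links it to compound 2, so it only shows that a strong effect is reachable.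

A rise is therefore expected, probably smaller than the full amount lost, with the estimated step of a number 27.8 percentage points higher from compound 2 to compound 4 (beyond the scatter). Compound 4 is expected to reach 45%, with a range from 20% to 70%.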

Compound 4, a percentage reported as inhibition, at one concentration (the size of the read-out at that concentration, not a potency): 87.1%
Compound 4: middle estimate off by 42.1 percentage points, on the low side, and the stated range ends below it.
By their numbers in this assay, from the lowest: compound 2; then compound 1; then compounds 3 and 4 (each within the scatter of the next).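

In this assay, putting pyridin-4-yl in place of 4-chlorophenyl on the ring nitrogen gives a number 69.9 percentage points higher from compound 2 to compound 4 (beyond the scatter), so an aromatic ring sitting directly on that nitrogen is compatible with a strong effect, and the weak read-out belongs to the 4-chlorophenyl group rather than to direct attachment as such. The comparison with the other pyridine-bearing piperazine-type compound, where pyridin-4-yl replaces (pyridin-2-yl)methyl, gives a number 21.9 percentage points higher from compound 1 to compound 4 (beyond the scatter), so in this pair the directly attached ring does better than the one carried on a linking group. Nothing measured here explains why these swaps change the read-out so much.

As far as these compounds go, it remains open whether the gain from 4-chlorophenyl to pyridin-4-yl comes from losing the chlorine or from gaining the ring nitrogen, a question that an unsubstituted phenyl group on the same nitrogen would help to separate. Likewise, pyridin-3-yl or pyridin-2-yl attached directly would show whether the place of the ring nitrogen matters, and since each number comes from one concentration, none of them gives a potency.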